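This account rests on a few compounds, and the source may have more. Where it says the series, first, only, none or still open, it means among the compounds named here.

Measured in a physicochemical assay for lipophilicity, read by HPLC; on this read-out higher numbers stand for higher lipophilicity and lower numbers for lower lipophilicity:
- compound 1 `Cc1ccc([C@H](C(=O)N(C)C)N2C(=O)[C@@H](C3Cc4ccccc4C3)NC(=O)[C@H]2CC(C)C)cn1`: 2.1
- compound 2 `Cc1ccc([C@H](C(=O)N2CCCC2)N2C(=O)[C@@H](C3Cc4ccccc4C3)NC(=O)[C@H]2CC(C)C)cn1`: 2.3

Among the compounds with values here, compound 1 has only one measured neighbour, and the two sit close together: a number 0.20 log units higher from compound 1 to compound 2 (within the scatter). That step concerns a different part of the molecule, a group on a carbonyl carbon, so it gives little guidance here.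

Compound 3 `CC(C)C[C@@H]1C(=O)N[C@H](C2Cc3ccccc3C2)C(=O)N1[C@@H](C(=O)N(C)C)c1ccc(O)nc1` differs from compound 1 by hydroxy in place of methyl on an aromatic carbon, with hydroxy in place of methyl on an aromatic carbon, next to the ring nitrogen. Within the data shown here, no measured step covers this change, so the forecast in this assay is a judgement from the change alone. A clear move downward, beyond the scatter, is expected: a number 0.90 log units lower from compound 1 to compound 3 (beyond the scatter). For compound 3 the estimated value is 1.2, with an expected range of 0.6 to 1.8.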

Compound 3, distribution coefficient: 1.3
Compound 3: middle estimate off by 0.10 log units, on the low side; measured number inside the range.
By their numbers in this assay, from the lowest: compound 3; then compounds 1 and 2 (each within the scatter of the next).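

In this assay, going from the 6-methylpyridin-3-yl group to the 6-hydroxypyridin-3-yl group gives a number 0.80 log units lower from compound 1 to compound 3 (beyond the scatter), and this is the first step shown that lies beyond the scatter. The earlier pair differed only in a group on a carbonyl carbon, so it said nothing about this place on the aromatic ring, which now proves able to move the number. No measurement at hand accounts for the drop. Hydroxy is the only replacement for methyl shown here, so where an amine or a carboxylic acid would fall remains open. Also open, as far as these compounds go, is whether the same swap would give a similar step with the pyrrolidin-1-yl amide of compound 2.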